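The source may report more compounds than this note shows. Statements on the series, on what has been measured and on what is new or still open speak of the compounds shown alone.

Compounds measured in an in vitro functional assay on HEK ts201 cells for antagonist activity at Neuronal acetylcholine receptor; alpha4/beta2 (Homo sapiens), read by fluorescence and calcium flux; on this read-out lower numbers stand for stronger inhibition and higher numbers for weaker inhibition:

- compound 1, `COc1ccc(OCCCCCN2CCCC(COC(=O)c3ccccc3N3C(=O)CC(C)C3=O)C2)cc1OC`: 8320 nM
- compound 2, `CC1CC(=O)N(c2ccccc2C(=O)OCC2CCCN(CCCCOc3ccc(Cl)c(Cl)c3)C2)C1=O`: 12300 nM
- compound 3, `O=C(OCC1CCCN(CCCc2ccccc2)C1)c1ccccc1N1C(=O)CC(CCc2ccccc2)C1=O`: 5130 nM

Of the three numbers, compound 2 gives the highest, but its gap to compound 1 lies within the scatter of this assay, so no order between those two can be read; only compound 3 stands clearly apart from compound 2. For the measured compounds named here, the one step that can be traced in a single place runs a 1.5-fold higher number from compound 1 to compound 2 (0.17 log units; within the scatter), where a 3,4-dichlorophenoxy replaced a (3,4-dimethoxyphenoxy)methyl on a saturated chain carbon, four bonds along the chain from an amine nitrogen in a ring.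

Compound 4, `CC1CC(=O)N(c2ccccc2C(=O)OCC2CCCN(CCCCCOc3ccc(Cl)c(Cl)c3)C2)C1=O`, has not yet been measured. It differs from compound 2 by (3,4-dichlorophenoxy)methyl in place of 3,4-dichlorophenoxy on a saturated chain carbon, four bonds along the chain from an amine nitrogen in a ring, so it carries the chain length of compound 1 together with the aryl ring of compound 2. Going by the values given here, no measured pair isolates this change alone; the step from compound 1 to compound 2 bears on it, since it includes the reverse chain change, and it stayed within the scatter. Compound 4 is therefore expected to land near compound 2, with a 1.2-fold lower number from compound 2 to compound 4 (0.09 log units; within the scatter) expected to remain within the scatter. The estimate for compound 4 in this assay is 10000 nM, in a range from 4000 nM to 25000 nM.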

Compound 4, half-maximal inhibitory concentration: 17400 nM
For compound 4 the middle estimate is 1.7-fold (0.24 log units) below the measured one, within the range that was stated.
By their numbers in this assay, from the lowest: compounds 3, 1, 2 and 4 (each within the scatter of the next, the first and the last beyond it).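

For the compounds shown here, compound 4 gives the first comparison in this assay that separates the two changes combined in the step from compound 1 to compound 2. Taken alone, the change to (3,4-dichlorophenoxy)methyl in place of 3,4-dichlorophenoxy on a saturated chain carbon, four bonds along the chain from an amine nitrogen in a ring, stays within the scatter (a 1.4-fold higher number from compound 2 to compound 4 (0.15 log units; within the scatter)), so the numbers show no order between these two chain lengths, whereas with the chain length held constant, 3,4-dichlorophenyl in place of 3,4-dimethoxyphenyl on an oxygen on a saturated carbon gives a modest step beyond it (a 2.1-fold higher number from compound 1 to compound 4 (0.32 log units; beyond the scatter)). Nothing shown here explains either step.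

From the compounds shown here alone, whether the result for the ring change holds at the shorter chain of compound 2 remains open, since the 3,4-dimethoxyphenoxy group appears only with the longer chain. Also open, going by these compounds, is how the number would respond to a still longer chain at this place, or to a phenyl ring carrying an amine or a carboxylic acid on the oxygen.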